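A few compounds are considered here, and "the series" means these few. Any claim that something is new, unique, unknown or untested is made for them only; others in the source may bear on it.

Compound 1, `CN(C)CCn1cnnc1-c1cc(Oc2ccc(NC(=O)N/N=C/c3ccc(F)cc3)cc2F)ccn1`: 1030 nM
Compound 2, `CN(C)CCn1cnnc1-c1cc(Oc2ccc(NC(=O)N/N=C/c3ccc(F)cc3F)cc2F)ccn1`: 810 nM
Compound 3, `CN(C)CCn1cnnc1-c1cc(Oc2ccc(NC(=O)N/N=C/c3ccc(O)cc3O)cc2F)ccn1`: 2860 nM

In a functional assay on MKN-45 cells (Homo sapiens) for cytotoxicity, read by MTT assay, with a stated time of 72 h (on this read-out higher numbers stand for weaker inhibition and lower numbers for stronger inhibition), compound 1 gives 1030 nM, the second highest of the three numbers. Its nearest neighbour is compound 2, which gives 810 nM, a step of a 1.3-fold lower number from compound 1 to compound 2 (0.10 log units; within the scatter). Furthest from it is compound 3, which gives 2860 nM, a step of a 2.8-fold higher number from compound 1 to compound 3 (0.44 log units; beyond the scatter).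

The compound that has not yet been measured is compound 4, `CN(C)CCn1cnnc1-c1cc(Oc2ccc(NC(=O)N/N=C/c3cccc(O)c3)cc2F)ccn1`. It differs from compound 1 in one place: 3-hydroxyphenyl in place of 4-fluorophenyl on a carbon with a double bond to nitrogen.

Among the compounds with values here, two measured steps bear on this change, since both exchange a fluorine-bearing phenyl for a hydroxyl-bearing phenyl on the same carbon: a 2.8-fold higher number from compound 1 to compound 3 (0.44 log units; beyond the scatter) and a 3.5-fold higher number from compound 2 to compound 3 (0.55 log units; beyond the scatter). Both were modest and went towards higher numbers. Within the data shown here, compound 4 carries a single hydroxyl at a different place on the ring, and no measured pair shows exactly this exchange, so the analogy is loose. On that basis the number for compound 4 in this assay is expected to rise by a modest step, a 1.7-fold higher number from compound 1 to compound 4 (0.24 log units; within the scatter), and is estimated at 1800 nM, within a range from 900 nM to 3600 nM.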

Compound 4, half-maximal inhibitory concentration: 1370 nM
Compound 4: the middle estimate sits 1.3-fold (0.12 log units) above what was measured, and the stated range covers the measured number.
By their numbers in this assay, from the lowest: compounds 2, 1 and 4 (each within the scatter of the next); then compound 3.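

In this assay, 3-hydroxyphenyl on the carbon with a double bond to nitrogen gives a 1.3-fold higher number from compound 1 to compound 4 (0.12 log units; within the scatter) in place of 4-fluorophenyl and a 1.7-fold higher number from compound 2 to compound 4 (0.23 log units; within the scatter) in place of 2,4-difluorophenyl, so both exchanges stay within the scatter. Until now the only hydroxyl-bearing phenyl at this place was the 2,4-dihydroxyphenyl of compound 3, and both steps from a fluorine-bearing phenyl to that group lay beyond the scatter; compound 4 shows that exchanging fluorine-bearing phenyl for hydroxyl-bearing phenyl does not always carry such a step. The two hydroxyl-bearing groups are themselves separated by a 2.1-fold lower number from compound 3 to compound 4 (0.32 log units; beyond the scatter), which is beyond the scatter, so the modest loss seen with compound 3 belongs to 2,4-dihydroxyphenyl among the listed compounds rather than to every hydroxyl-bearing phenyl.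

The compounds shown cannot separate the place of a hydroxyl from the presence of a second one, and they leave open how 4-hydroxyphenyl, a methoxy-bearing phenyl, an amino-bearing phenyl or a carboxylic acid on the ring would behave at this carbon. Nothing available here explains any of these steps.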